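Oxadiazole series: methylpyridyl exchanged for difluoromethylpyridyl

The source may report more compounds than this note shows. Statements on the series, on what has been measured and on what is new or still open speak of the compounds shown alone.

Measured compounds:
compound 1 `Cc1cccc(-c2noc(C(C)NC(=O)c3cc(C4CC4)nn3C)n2)c1` — 1880 nM
compound 2 `Cc1cccc(-n2cc(C(C)NC(=O)c3cc(C(F)(F)F)nn3C)cn2)c1` — 1600 nM
compound 3 `Cc1ccnc(-c2noc([C@H](C)NC(=O)c3cc(C(F)(F)F)nn3C)n2)c1` — 4470 nM

In an assay on T-REx-293 cells for inhibition of potassium channel subfamily T member 1 (Homo sapiens), read by patch clamp (on this read-out lower numbers stand for stronger inhibition and higher numbers for weaker inhibition), compound 1 gives 1880 nM, compound 2 gives 1600 nM and compound 3 gives 4470 nM. Compound 3 stands highest of the three; compound 1 is nearest and compound 2 furthest, both gaps lying beyond the scatter. For the measured compounds named here, no two measured compounds differ in a single place, so no step between measured compounds is available.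

Compound 4 `C[C@H](NC(=O)c1cc(C(F)(F)F)nn1C)c1nc(-c2ccnc(C(F)F)c2)no1` differs from compound 3 in one place: a group of 9 heavy atoms (6 carbon, 1 nitrogen, 2 fluorine; one six-membered aromatic ring with 1 hetero atom) in place of a group of 7 heavy atoms (6 carbon, 1 nitrogen; one six-membered aromatic ring with 1 hetero atom), on an aromatic carbon

The measured set gives no direct guide to this exchange. For compound 4 a step of a 1.5-fold lower number from compound 3 to compound 4 (0.17 log units; within the scatter) from compound 3 is expected, most likely small and possibly within the scatter. Compound 4 is estimated at 3000 nM, with a range from 1000 nM to 9000 nM.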

Compound 4, half-maximal inhibitory concentration: 61 nM
Compound 4: middle estimate off by 49-fold (1.69 log units), on the high side, outside the stated range (below it).
By their numbers in this assay, from the lowest: compound 4; then compounds 2 and 1 (each within the scatter of the next); then compound 3.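

In this assay, for the compounds shown here, the difluoromethylpyridyl group in place of 4-methylpyridin-2-yl, on the aromatic carbon between two ring nitrogen atoms, gives a 73-fold lower number from compound 3 to compound 4 (1.86 log units; beyond the scatter), the first single-place step in this set. The pyridine substituent at this position therefore strongly affects inhibition, although the ring type and the hydrogen-bond donor and acceptor counts stay unchanged. Nothing available explains the size of this step.

As far as these compounds go, whether a trifluoromethyl, chloro or methoxy group on the same pyridine would match compound 4 remains open. So does whether the same exchange would give a similar step with the cyclopropyl group of compound 1 in place of trifluoromethyl.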